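The compounds below may be only part of what the source reports. "The series", "measured", "known", "first", "only" and "open" are said of these compounds alone.

Of the compounds shown here, two have so far been tested in a functional assay on A549 cells (Homo sapiens) for inhibition, read by MTT assay, with a stated time of 24 h; a lower number here means a stronger inhibitor, a higher number a weaker inhibitor. Going by the values given here, compound 1 `CCOC(=O)C1=Cc2ccccc2OC1(OCc1cn(CC(=O)Nc2cccc(Cl)c2)nn1)C(F)(F)F` gives 12800 nM in this assay, the lowest of the two numbers known. Compound 2 `Cc1ccc(-c2cc(COC3(C(F)(F)F)Oc4ccccc4C=C3C(=O)O)on2)cc1` gives 51200 nM in this assay, a number that lies beyond the usual scatter from that of compound 1; the two compounds differ in several places at once, so no single step can be read from them.

Compound 3 `CCOC(=O)C1=Cc2ccccc2OC1(OCc1cn(CC(=O)Nc2cccc(F)c2)nn1)C(F)(F)F` has not yet been measured in this assay. It differs from compound 1 in one place: fluoro in place of chloro on an aromatic carbon. Among the compounds with values here, no measured pair in this set shows what this exchange does, so the expectation rests on the change itself, which involves one heavy atom leaving and one entering, with no change in donors, acceptors or charge. The expected step, a 1.4-fold higher number from compound 1 to compound 3 (0.15 log units; within the scatter), is a small move toward a higher number that may well stay within the scatter. Compound 3 is therefore estimated at 18000 nM in this assay, with a range from 6000 nM to 55000 nM.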

Compound 3, half-maximal inhibitory concentration: > 150000 nM
Compound 3: no number, only a limit; the forecaster's own chance of this, stated with the estimate: 15%; middle value at least 8.3-fold (0.92 log units) from the limit.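

Exchanging chloro for fluoro on an aromatic carbon of the 3-chlorophenyl ring moves one heavy atom out and one in, with no change in hydrogen-bond donors, acceptors or charge, yet it gives an at least 11-fold higher number from compound 1 to compound 3 (1.06 log units; beyond the scatter). Going by these compounds alone, this is the first single-place step in the set, since compound 1 and compound 2 differ in several places at once, and it shows that the halogen at this position is not freely interchangeable, even though the change itself is so small. Compound 3 in this assay gives a limit, not a number: the limit of > 150000 nM in this assay, at which 1 of the 3 values shown sits.

As far as these compounds go, this single pair does not show whether chloro is specifically favoured here, so it remains open how a bromo, a methyl or a methoxy group at the same place would read, or a plain phenyl ring with no group there at all. Also open, from the compounds shown here alone, is whether the same exchange would have a similar effect with a carboxylic acid in place of the ethyl ester.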